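Replacing a Cyanobenzyl Group with Phenyl: Expected Permeability

The source may report more compounds than this note shows. Statements on the series, on what has been measured and on what is new or still open speak of the compounds shown alone.

Three compounds share one core and differ only in the group attached to it. Compound 1 `COc1ccc(F)cc1CNCCCNc1ccnc2cc(Cc3cc(C)cc(C)c3)ccc12` carries a 3,5-dimethylphenyl group on a saturated chain carbon, compound 2 `COc1ccc(F)cc1CNCCCNc1ccnc2cc(Cc3ccc(F)cc3)ccc12` a 4-fluorophenyl group in the same place, and compound 3 `COc1ccc(F)cc1CNCCCNc1ccnc2cc(Cc3ccc(C#N)cc3)ccc12` a 4-cyanophenyl group there. In an ADME assay for permeability, using PAMPA, with a stated time of 30 min, at pH 7.4 (a lower number here means that the compound crosses the layer more slowly, a higher number that the compound crosses the layer faster), compound 1 gives 23 10^-6 cm/s, compound 2 gives 23 10^-6 cm/s, and compound 3 gives 23 10^-6 cm/s. The three values lie level with one another: no change at the digits printed from compound 1 to compound 2 (within the scatter), no change at the digits printed from compound 1 to compound 3 (within the scatter), and no change at the digits printed from compound 2 to compound 3 (within the scatter).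

Compound 4 `COc1ccc(F)cc1CNCCCNc1ccnc2cc(-c3ccccc3)ccc12` differs from compound 3 in this way: phenyl in place of 4-cyanobenzyl on an aromatic carbon. This change is of a different kind from the measured ones. Each measured step swapped one group for another on the saturated chain carbon, and none of those swaps moved the value beyond the scatter. Among the compounds with values here, no measured step removes the saturated chain carbon itself or the nitrile, so the data say nothing direct about that part of the change. Given that every swap so far left this assay unchanged, the step from compound 3 to compound 4 is expected to be no change at the digits printed from compound 3 to compound 4 (within the scatter), within the scatter. Compound 4 is therefore estimated at 23 10^-6 cm/s, with a range from 12 10^-6 cm/s to 42 10^-6 cm/s.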

Compound 4, apparent permeability: 237 10^-6 cm/s
The estimate for compound 4 lay 10-fold (1.01 log units) below the measured number; measured number above the stated range.
By their numbers in this assay, from the lowest: compounds 1, 2 and 3 (each within the scatter of the next); then compound 4.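

In this assay, replacing the benzyl-type group with a phenyl bound directly to the aromatic carbon gives a 10-fold higher number from compound 3 to compound 4 (1.01 log units; beyond the scatter) and gives a 10-fold higher number from compound 2 to compound 4 (1.01 log units; beyond the scatter) and also a 10-fold higher number from compound 1 to compound 4 (1.01 log units; beyond the scatter) as the same change is read from the other two compounds. This position therefore stayed flat while the group on the far ring varied across compounds 1, 2 and 3, yet it responds strongly once the saturated chain carbon is gone and the ring sits directly on the core. The step has the same size whichever group leaves, and compounds 1 and 2 carry no nitrile, so loss of the nitrile is not needed for the rise.

Nothing available here gives a reason for the rise. From the compounds shown here alone, each of these steps removes the saturated chain carbon and any substituent on the far ring together, so it stays open which part matters; an unsubstituted benzyl group would separate the two, and it is also open how a longer chain or an amine on the phenyl ring would read.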